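Amide variation on the shared core: clearance notes

The source may report more compounds than this note shows. Statements on the series, on what has been measured and on what is new or still open speak of the compounds shown alone.

Three compounds of this series have been run in an ADME assay on microsomes from liver (Homo sapiens) for metabolic stability, read by LC-MS, using NADPH, with a stated time of 45 min, tested at 0.5 uM; a lower number here means slower removal, a higher number faster removal of the compound. Compound 1 `O=C(CCSc1nc2cc(Cl)ccc2o1)NC1CCCC1` gives 11.3 mL/min/g in this assay, the highest of the three numbers. Compound 2 `O=C(CCSc1nc2ccccc2o1)N1CCCC1` gives 5.1 mL/min/g in this assay, and its gap to compound 1 lies beyond the scatter. Compound 3 `CS(=O)(=O)N1CCN(C(=O)CCSc2nc3cc(Cl)ccc3o2)CC1` gives 0.6 mL/min/g in this assay, the lowest of the three and well beyond the scatter from compound 1. No two of these compounds differ in one place only, so no single-change step can be read from them; what they show is that every variation of the amide end seen so far has come with a lower number than compound 1.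

Compound 4 `CN(C)C(=O)CCSc1nc2cc(Cl)ccc2o1` differs from compound 1 at the amide: dimethylamino in place of cyclopentylamino on a carbonyl carbon. Among the measured compounds shown here, with no measured single-change step to lean on, a moderate downward step in this assay is expected, beyond the scatter, because compound 2 gives 5.1 mL/min/g and compound 3 gives 0.6 mL/min/g, both carrying other amides and both under compound 1. Compound 4 is therefore expected to give about 5 mL/min/g in this assay, within a range from 2 mL/min/g to 12 mL/min/g. This estimate implies a step of a 2.3-fold lower number from compound 1 to compound 4 (0.35 log units; beyond the scatter), expected to fall beyond the scatter.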

Compound 4, intrinsic clearance in a liver preparation (reported as CLH), per the amount of preparation that the assay uses: 2.7 mL/min/g
Estimate against measurement, compound 4: 1.9-fold (0.27 log units) above; the measured number falls inside the stated range.
By their numbers in this assay, from the lowest: compound 3; then compounds 4 and 2 (each within the scatter of the next); then compound 1.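

The amide end now has its first single-change reading in this assay: dimethylamino in place of cyclopentylamino on a carbonyl carbon gives a 4.2-fold lower number from compound 1 to compound 4 (0.62 log units; beyond the scatter), which shows that this place alone, with the rest of the structure held fixed, can move the number by more than the scatter. The change takes out a group of 6 heavy atoms with a five-membered non-aromatic ring of carbon only and 1 hydrogen-bond donor and puts in one of 3 heavy atoms with no ring and 0 hydrogen-bond donors, so the ring, the size of the group and the amide hydrogen all change together in this single step and cannot be told apart. Nothing among the data shown speaks to why the number falls.

The compounds shown leave open how methylamino, which would keep the amide hydrogen without a ring, and cyclopentyl(methyl)amino, which would keep the ring without the amide hydrogen, would read against compound 1 in this assay. They also leave open whether the same change on a carbonyl carbon gives a step of similar size on the core of compound 2.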